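A few compounds are considered here, and "the series" means these few. Any claim that something is new, unique, unknown or untested is made for them only; others in the source may bear on it.

Measured compounds:
- Compound 1 `COc1ccc(N(C(=O)CN2C=CN(c3ccccc3)C(=O)C(Cc3n[nH]c4ccccc34)C2=O)C(C)C)cc1`: 29.5 nM
- Compound 2 `CC(C)N(C(=O)CN1C=CN(c2ccccc2)C(=O)C(Cc2n[nH]c3ccccc23)C1=O)c1ccc(O)cc1`: 550 nM; 158 nM; 52.5 nM (3 entries)
- Compound 3 `COc1ccc(N(C(=O)CN2C=CN(c3ccccc3)C(=O)[C@H](Cc3n[nH]c4ccccc34)C2=O)C(C)C)cc1`: 15.9 nM

Compound 1 gives 29.5 nM in a functional assay on CHO cells for agonist activity at Melanocyte-stimulating hormone receptor (Homo sapiens), read by a luciferase reporter, with a stated time of 4 h; on this read-out higher numbers stand for an effect only at larger amounts of compound and lower numbers for an effect already at smaller amounts. Among the two compounds with a single number, compound 1 holds the higher one; the step of a 1.9-fold lower number from compound 1 to compound 3 (0.27 log units; within the scatter) stays within the usual scatter, and the two compounds differ only in that one is drawn with a defined configuration at a saturated ring carbon and the other without, as the fact that one of compounds 1 and 3 is drawn with a defined configuration and the other without, at the place where they differ records. Compound 2 has been measured three times with widely spread results, (the several entries of compound 2 in this assay, 550 nM; 158 nM; 52.5 nM (3 entries)), so it gives no single number to compare against.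

Compound 4 `CC(C)N(C(=O)CN1C=CN(c2ccccc2)C(=O)C(Cc2n[nH]c3ccccc23)C1=O)c1ccc(OC(F)(F)F)cc1` is not yet measured. It differs from compound 1 by trifluoromethyl in place of methyl on an oxygen on an aromatic ring, that is, a methoxy group becomes a trifluoromethoxy group on the phenyl ring of the amide. Among the compounds with values here, none of the measured steps touches this part of the molecule: the one defined step concerns the stereocentre, and the phenol of compound 2 is a different change at this place whose spread of values allows no firm reading. The step from compound 1 to compound 4 is therefore expected to be small, a 1.4-fold higher number from compound 1 to compound 4 (0.13 log units; within the scatter), with wide uncertainty in either direction. Compound 4 is estimated at 40 nM in this assay, within a range from 8 nM to 200 nM.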

Compound 4, half-maximal effective concentration: 22.4 nM
Compound 4: the middle estimate sits 1.8-fold (0.25 log units) above what was measured; low and high end bracket the measured number.
By their numbers in this assay, from the lowest: compounds 3, 4 and 1 (each within the scatter of the next).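

Swapping methyl for trifluoromethyl on the oxygen gives a 1.3-fold lower number from compound 1 to compound 4 (0.12 log units; within the scatter) in this assay, so this step cannot be told apart from repeat scatter, even though the entering group carries 4 heavy atoms where the leaving one carries 1. Within the data shown here, this is the first readable step at this place on the aromatic ring, since the other change here, the free hydroxyl of compound 2, gives entries too widely spread to compare: the several entries of compound 2 in this assay, 550 nM; 158 nM; 52.5 nM (3 entries). Nothing shown here gives a reason why the number stays within the scatter for this change.

Going by these compounds, a single step at this position cannot show how far the same outcome extends, so it remains open whether an ethoxy group, a longer chain, an amine or a carboxylic acid on the aromatic ring would also stay within the scatter of compound 1. On these data alone, it is also open whether compound 4 would behave as compound 3 does when drawn with a defined configuration at the saturated ring carbon, since compound 4 carries none at that stereocentre.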